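Swapping a Carboxy Group for Imidazolyl on a Weak Scaffold

This account rests on a few compounds, and the source may have more. Where it says the series, first, only, none or still open, it means among the compounds named here.

Compound 1 `COC(=O)c1cc2ccccc2n1[C@@H]1c2cc(C#N)ccc2OC(C)(C)[C@H]1O` gives 33000 nM in a functional assay (aorta) with Rattus norvegicus as the target; on this read-out lower numbers stand for stronger inhibition and higher numbers for weaker inhibition. Compound 2 `CCOC(=O)CN(c1ccccc1)[C@@H]1c2cc(C#N)ccc2OC(C)(C)[C@H]1O` reaches only a limit of the measurement, > 30000 nM, in this assay. Compound 3 `CC1(C)Oc2ccc(C#N)cc2[C@H](N(CC(=O)O)c2ccccc2)[C@H]1O` likewise stops at a limit, > 100000 nM, in this assay, so of the three values shown it is one of two that are limits rather than numbers. Compound 4 `CC1(C)Oc2ccc(C#N)cc2[C@H](N(Cc2ncc[nH]2)c2ccccc2)[C@H]1O` has not been tested; it differs from compound 3 by one change, (1H-imidazol-2-yl in place of carboxy on a saturated chain carbon bound to a nitrogen on an aromatic ring). Among the measured compounds shown here, no step between tested compounds covers this change, so its size is open. The step is expected to move toward stronger inhibition, an at least 5.0-fold lower number from compound 3 to compound 4 (0.69 log units; beyond the scatter), though every tested compound inhibits weakly. Compound 4 is expected to give about 20000 nM, between 4000 nM and 100000 nM, in this assay.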

Compound 4, half-maximal inhibitory concentration: > 30000 nM
Compound 4 was reported as a limit (the forecaster's own chance of this, stated with the estimate: 40%); at least 1.5-fold (0.17 log units) between middle value and limit.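

Compound 3 and compound 4 are both reported only as limits, so the step between them cannot be read. The compounds shown leave open whether 1H-imidazol-2-yl in place of carboxy changes inhibition at all.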